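One carbon shorter on the chain of compound 3

A few compounds are considered here, and "the series" means these few. Any claim that something is new, unique, unknown or untested is made for them only; others in the source may bear on it.

Measured in a functional assay on the whole organism with Mus musculus as the target, in the writhing test; a higher number here means that more compound is needed for the effect, a lower number that less compound is needed:
Compound 1, `CCCCCn1nc2oc(=O)cc(C)c2c1C`, gives 60.6 mg/kg.
Compound 2, `CCn1nc2oc(=O)cc(C)c2c1C`, gives 14.6 mg/kg.
Compound 3, `CCCCn1nc2oc(=O)cc(C)c2c1C`, gives only a limit of the assay, > 100 mg/kg.

Compound 3 therefore stands at the limit of > 100 mg/kg in this assay, at which 1 of the 3 values shown sits, with an at least 6.8-fold higher number from compound 2 to compound 3 (0.83 log units; beyond the scatter) and an at least 1.6-fold higher number from compound 1 to compound 3 (0.21 log units; that floor lies within the scatter). Compound 4, `CCCn1nc2oc(=O)cc(C)c2c1C`, differs from compound 3 by hydrogen in place of methyl on a saturated chain carbon, three bonds along the chain from an aromatic nitrogen. For the measured compounds named here, two measured steps bear on this: removing three chain carbons gave a 4.2-fold lower number from compound 1 to compound 2 (0.62 log units; beyond the scatter), while removing one carbon further out gave only a floor inside the scatter. Shortening the chain is thus expected to lower the number in this assay modestly, though compound 1 shows the trend is not uniform. Compound 4 is expected at 40 mg/kg, between 12 mg/kg and 130 mg/kg, which would mean an estimated at least 2.5-fold lower number from compound 3 to compound 4 (0.39 log units; beyond the scatter).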

Compound 4, dose for half-maximal effect: 72.6 mg/kg
Estimate against measurement, compound 4: 1.8-fold (0.26 log units) below, within the range that was stated.
By their numbers in this assay, from the lowest: compound 2; then compounds 1 and 4 (each within the scatter of the next). At a limit, above all of these: compound 3.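

In this assay, the step up from the ethyl chain to the propyl chain already accounts for a clear rise, with a 5.0-fold higher number from compound 2 to compound 4 (0.70 log units; beyond the scatter), while the longest chain shown stays level, with a 1.2-fold higher number from compound 1 to compound 4 (0.08 log units; within the scatter). Taking the methyl off at this place gives only an at least 1.3-fold lower number from compound 3 to compound 4 (0.13 log units; that floor lies within the scatter), so the size of this change cannot be fixed. Adding the same piece of chain has a different outcome on the two cores, and chain length does not act in even increments: the same change on two cores in this assay, an at least 6.8-fold higher number (0.83 log units; beyond the scatter) from compound 2 to compound 3 and a 1.2-fold lower number (0.08 log units; within the scatter) from compound 4 to compound 1, at least 8.2-fold (0.91 log units) apart, beyond the scatter of two such steps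

From the compounds shown here alone, what a branched chain or an amine at the chain end would give stays open. So does the true value of compound 3, whose > 100 mg/kg is a limit.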